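A few compounds are considered here, and "the series" means these few. Any claim that something is new, unique, unknown or untested is made for them only; others in the source may bear on it.

Of the compounds shown here, three that share one core have been measured in a physicochemical assay for solubility, read by spectrophotometry, in phosphate buffer, with a stated time of 18 h, at pH 7.4 (on this read-out lower numbers stand for lower solubility and higher numbers for higher solubility), and they differ only in the aromatic group on a single carbon. Compound 1 `Cc1ccccc1-c1nc2c(c(C)nn2-c2ccccc2)c(-c2ccccc2O)c1C#N`, with 2-methylphenyl, gives 21000 nM. Compound 2 `CCCc1ccc(-c2nc3c(c(C)nn3-c3ccccc3)c(-c3ccccc3O)c2C#N)cc1`, with 4-propylphenyl, gives 6500 nM. Compound 3 `Cc1nn(-c2ccccc2)c2nc(-c3ccc4ccccc4c3)c(C#N)c(-c3ccccc3O)c12`, with naphthalen-2-yl, gives 1800 nM, the lowest of the three numbers.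

Compound 4 `Cc1nn(-c2ccccc2)c2nc(-c3ccc(F)cc3)c(C#N)c(-c3ccccc3O)c12` keeps the core and puts 4-fluorophenyl in place of naphthalen-2-yl (4-fluorophenyl in place of naphthalen-2-yl on an aromatic carbon). The change sits on an aromatic carbon next to the ring nitrogen and ortho to a cyano group.

All three measured steps concern this same carbon. Moving to naphthalen-2-yl gave a large drop in a 12-fold lower number from compound 1 to compound 3 (1.07 log units; beyond the scatter) and a modest one in a 3.6-fold lower number from compound 2 to compound 3 (0.56 log units; beyond the scatter). The two single-ring groups themselves lie apart, as a 3.2-fold lower number from compound 1 to compound 2 (0.51 log units; beyond the scatter) shows, so a single ring does not fix the number closely. Among the compounds with values here, none of the measured compounds carries fluorine, which leaves the size uncertain.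

Compound 4 has one ring where compound 3 has two, so its number is expected to rise, probably landing among those of the single-ring compounds. The expected change is a 5.0-fold higher number from compound 3 to compound 4 (0.70 log units; beyond the scatter), a modest to large step upward. For compound 4 the estimated value is 9000 nM, with an expected range from 3500 nM to 23000 nM.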

Compound 4, solubility: 6000 nM
The estimate for compound 4 lay 1.5-fold (0.18 log units) above the measured number; measured number inside the range.
By their numbers in this assay, from the lowest: compound 3; then compounds 4 and 2 (each within the scatter of the next); then compound 1.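

In this assay the swap gives a 3.3-fold higher number from compound 3 to compound 4 (0.52 log units; beyond the scatter) so that compound 3, the only one here with naphthalen-2-yl, now sits beyond the scatter from all three compounds with a single ring at this carbon. Among those single-ring compounds, fluoro in place of propyl gives a 1.1-fold lower number from compound 2 to compound 4 (0.03 log units; within the scatter) and leaves compound 2 and compound 4 indistinguishable despite the different substituents, whereas the change from the 2-methylphenyl group gives a 3.5-fold lower number from compound 1 to compound 4 (0.54 log units; beyond the scatter) and so sets compound 1 apart from compound 4 by more than the scatter. No measurement shown here accounts for these differences.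

Still open, from the compounds shown here alone, is whether 4-methylphenyl would fall with compound 1 or with compound 2 and compound 4, which would help separate the identity of the substituent from its place on the ring. Also open is how the number would respond to an amine or a carboxylic acid on the phenyl ring at this carbon, as every substituent shown on that ring is a fluoro or a simple carbon chain.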